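A few compounds are considered here, and "the series" means these few. Any claim that something is new, unique, unknown or untested is made for them only; others in the source may bear on it.

In a functional assay on A549 cells (Homo sapiens) for inhibition, read by sulforhodamine B assay (a lower number here means a stronger inhibitor of growth, a higher number a weaker inhibitor of growth), compound 1 `c1ccc(-c2ccc(-c3ccc(-c4nc5ccccc5[nH]4)cc3)cc2)cc1` gives 41200 nM, compound 2 `Fc1ccc(-c2ccc(-c3ccc(-c4nc5ccccc5[nH]4)cc3)cc2)cc1` gives 33200 nM, and compound 3 `Oc1cccc2[nH]c(-c3ccc(-c4ccc(-c5ccccc5)cc4)cc3)nc12` gives 8320 nM, the lowest of the three numbers. The change leading to compound 4 `Oc1cccc2[nH]c(-c3ccc(-c4ccc(-c5ccc(F)cc5)cc4)cc3)nc12` is fluoro in place of hydrogen on an aromatic carbon, para to a large group. Among the measured compounds shown here, the same exchange gave a 1.2-fold lower number from compound 1 to compound 2 (0.09 log units; within the scatter), the closest precedent. The hydroxy exchange gave a 5.0-fold lower number from compound 1 to compound 3 (0.69 log units; beyond the scatter), but that is a different change, and its hydroxy group is already present in compound 3. No step beyond the scatter is therefore expected in this assay. The expected step is a 1.2-fold lower number from compound 3 to compound 4 (0.08 log units; within the scatter). For compound 4 the estimated value is 7000 nM, with an expected range of 3500 nM to 14000 nM.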

Compound 4, concentration for 50% growth inhibition: 170 nM
Compound 4: the middle estimate sits 41-fold (1.61 log units) above what was measured; the whole stated range lies above it.
By their numbers in this assay, from the lowest: compound 4; then compound 3; then compounds 2 and 1 (each within the scatter of the next).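

In this assay phenyl to 4-fluorophenyl gives a 49-fold lower number from compound 3 to compound 4 (1.69 log units; beyond the scatter) and so the size of this exchange depends on the core that carries it: the same change on two cores in this assay, a 1.2-fold lower number (0.09 log units; within the scatter) from compound 1 to compound 2 and a 49-fold lower number (1.69 log units; beyond the scatter) from compound 3 to compound 4, 39-fold (1.60 log units) apart, beyond the scatter of two such steps.
Hydroxy in place of hydrogen likewise gives a 200-fold lower number from compound 2 to compound 4 (2.29 log units; beyond the scatter) with the fluoro group present, so the two changes do not add independently in these compounds: the same change on two cores in this assay, a 5.0-fold lower number (0.69 log units; beyond the scatter) from compound 1 to compound 3 and a 200-fold lower number (2.29 log units; beyond the scatter) from compound 2 to compound 4, 39-fold (1.60 log units) apart, beyond the scatter of two such steps.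

As far as these compounds go, whether the para position needs fluoro itself or would accept chloro or methoxy remains open. Also open, from the compounds shown here alone, is whether an amine could stand in for the hydroxy group and keep the same dependence.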